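Aromatic amine in place of tert-butyl on a shared core

The source may report more compounds than this note shows. Statements on the series, on what has been measured and on what is new or still open speak of the compounds shown alone.

Measured so far:
- compound 1, `CC(C)(C)Nc1nc(N)c(C(=O)N=C(N)N)nc1Cl`: 48%
- compound 2, `NC(N)=NC(=O)c1nc(Cl)c(N2CCc3ccccc32)nc1N`: 89%

Both compounds were tested in an assay for inhibition of acid-sensing ion channel 3 (Homo sapiens), read by patch clamp, tested at 20 uM; a higher number here means more inhibition at the concentration tested (going by the name of the read-out), a lower number less inhibition. Compound 1 gives 48%, the lowest of the two numbers. Compound 2, with its own larger change on the same core, gives 89%, a gap beyond the usual scatter of such measurements. For the measured compounds named here, no single-point step between measured compounds is available, so the effect of swapping one group on the nitrogen cannot be read off directly.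

Compound 3, `NC(N)=NC(=O)c1nc(Cl)c(Nc2ccccn2)nc1N`, has not yet been measured in this assay. It differs from compound 1 in one place: pyridin-2-yl in place of tert-butyl on a nitrogen on an aromatic ring. Since compound 2 shows that a ring-bearing substitution at this part of the core goes with a higher inhibition, a moderate rise is expected, though the two structures are not directly comparable. The step from compound 1 to compound 3 is estimated at a number 17 percentage points higher from compound 1 to compound 3 (beyond the scatter). For compound 3 the expected inhibition in this assay is 65%, with a likely range from 40% to 88%.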

Compound 3, a percentage reported as inhibition, at one concentration (the size of the read-out at that concentration, not a potency): 25%
Compound 3: the middle estimate sits 40 percentage points above what was measured; measured number outside the range, below it.
By their numbers in this assay, from the lowest: compound 3; then compound 1; then compound 2.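

In this assay, for the compounds shown here, the swap of tert-butyl for pyridin-2-yl on this nitrogen gives a number 23 percentage points lower from compound 1 to compound 3 (beyond the scatter) as the first step that isolates this one place. It shows that putting an aromatic ring on this nitrogen does not by itself go with more inhibition, since here the pyridin-2-yl group sits with the lower number and tert-butyl with the higher. The data shown give no measured property of either group that would explain the drop.

The compounds shown leave open whether the ring nitrogen of pyridin-2-yl matters, which a plain phenyl group on the same nitrogen would help to settle. Also open, on these data alone, is how a benzyl group or a cyclohexyl ring, each in place of tert-butyl, would compare on the shared core.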